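Swapping Fluoro for Hydrogen on Compound 3

The source may report more compounds than this note shows. Statements on the series, on what has been measured and on what is new or still open speak of the compounds shown alone.

In an ADME assay on CHO cells (Cricetulus griseus) for cytotoxicity, read by MTT assay (a lower number here means a stronger inhibitor, a higher number a weaker inhibitor), compound 1 `COc1ccc(C(=O)/C=C/c2ccc(CN3CCCCC3)c(O)c2)cc1` gives 197000 nM, and compound 2 `Oc1ccc(CCCc2ccc(C(F)(F)F)cc2)cc1CN1CCCCC1` gives 23100 nM. Compound 3 `Oc1cc(CCCc2ccc(F)cc2)ccc1CN1CCCCC1` gives 163000 nM, a number within the scatter of compound 1 and beyond the scatter above compound 2.

Compound 4 `Oc1cc(CCCc2ccccc2)ccc1CN1CCCCC1` differs from compound 3 by one change, hydrogen in place of fluoro on an aromatic carbon. Among the measured compounds shown here, no two measured compounds differ in only one place, so the data offer no direct guide to this swap. The estimated step is a 1.1-fold lower number from compound 3 to compound 4 (0.04 log units; within the scatter), which is expected to stay within the scatter in this assay, with no clear direction. For compound 4 the estimated value is 150000 nM, with an expected range from 70000 nM to 300000 nM.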

Compound 4, half-maximal inhibitory concentration: 162000 nM
The estimate for compound 4 lay 1.1-fold (0.03 log units) below the measured number; measured number inside the range.
By their numbers in this assay, from the lowest: compound 2; then compounds 4, 3 and 1 (each within the scatter of the next).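

Among the compounds shown here, replacing fluoro with hydrogen on the aromatic ring gives a 1.0-fold lower number from compound 3 to compound 4 (0.00 log units; within the scatter) in this assay and is the first change here that can be read on its own. At this place, para to a large group, 4-fluorophenyl and phenyl therefore cannot be told apart in cytotoxicity on these cells. No measured evidence bears on why this swap leaves the number in place.

As far as these compounds go, whether a chloro, methoxy or amine group at the same place would also read alike stays open. So does whether this holds on the other cores shown.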